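Lengthening a Side Chain on a Shared Core

A few compounds are considered here, and "the series" means these few. Any claim that something is new, unique, unknown or untested is made for them only; others in the source may bear on it.

Compound 1, `CCCCCCCCCCCCC/C=C/[C@@H](O)[C@H](CO)n1cc(CCCCCC)nn1`: 8200 nM
Compound 2, `CCCCCCCCCCCCCC[C@@H](O)[C@@H](O)[C@H](CO)n1cc(CCCC)nn1`: 14500 nM
Compound 3, `CCCCCCCCCCCCCCCCCCCCCCCCc1cn([C@@H](CO)[C@H](O)[C@H](O)CCCCCCCCCCCCCC)nn1`: a limit of the assay, > 50000 nM

All three were tested in a functional assay on K562 cells (Homo sapiens) for cytotoxicity, read by MTT assay; on this read-out higher numbers stand for an effect only at larger amounts of compound and lower numbers for an effect already at smaller amounts. Compound 1 holds the lowest of the two numbers shown, but compound 2 sits so close to it that the gap lies within the usual scatter, so neither can be called more active than the other. Compound 3 reaches only the limit of this assay, with no number reported; this is the only limit among the three, (the limit of > 50000 nM in this assay, at which 1 of the 3 values shown sits).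

Compound 4, `CCCCCCCCCCCCC/C=C/[C@@H](O)[C@H](CO)n1cc(CCCCCCCCCCCCC)nn1`, has not yet been measured. It differs from compound 1 in one place: heptyl in place of hydrogen on a saturated chain carbon, six bonds along the chain from an aromatic carbon. Within the data shown here, no measured pair isolates this change, so the expectation rests on the wider picture. Compound 3, which carries a much longer chain on the core, gave only a limit, > 50000 nM, which makes a weaker result for the longer chain the more likely outcome. The step from compound 1 to compound 4 is therefore expected to move toward higher numbers, beyond the scatter, a 2.7-fold higher number from compound 1 to compound 4 (0.43 log units; beyond the scatter). Compound 4 is estimated at 22000 nM, with a range from 8000 nM to 50000 nM.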

Compound 4, half-maximal effective concentration: > 50000 nM
Compound 4 was reported as a limit; the forecaster's own chance of this, stated with the estimate: 30%; middle value at least 2.2-fold (0.35 log units) from the limit.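

Among these compounds, compound 1 and compound 4 differ in one place, so this is the first change here that can be read on its own: heptyl in place of hydrogen on a saturated chain carbon, six bonds along the chain from an aromatic carbon. In this assay this longer chain gives an at least 6.0-fold higher number from compound 1 to compound 4 (0.78 log units; beyond the scatter) and so takes the result clearly beyond the scatter. As far as these compounds go, compound 4 gives a limit and not a number, so the full size of the step stays unknown, and the measured series now ends twice at the same limit: the limit of > 50000 nM in this assay, at which 2 of the 4 values shown sit.

The compounds shown leave open how a chain of intermediate length, such as octyl, would behave in this place. They also leave open whether a chain of this length ending in an amine or a carboxylic acid would give a measurable number, and they do not show why the longer chain has this effect.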